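A few compounds are considered here, and "the series" means these few. Any claim that something is new, unique, unknown or untested is made for them only; others in the source may bear on it.

Compound 1 `CCN(Cc1ccc(-c2ccnc3ccc(-c4cnc(OC)c(NS(=O)(=O)c5ccc(F)cc5F)c4)cc23)cc1)C1CCCCC1` is examined in a functional assay on A549 cells (Homo sapiens) for cytotoxicity, read by MTT assay, with a stated time of 72 h (a lower number here means a stronger inhibitor, a higher number a weaker inhibitor), where compound 1 gives 20.2 nM. On the numbers shown, compound 1 carries the higher of the two values, but its only neighbour, compound 2 `COc1ncc(-c2ccc3nccc(-c4ccc(CN5CCCCC5)cc4)c3c2)cc1NS(=O)(=O)c1ccc(F)cc1F` with 15.5 nM, sits a 1.3-fold lower number from compound 1 to compound 2 (0.12 log units; within the scatter) away, so the two cannot be told apart. Compound 3 `COc1ncc(-c2ccc3nccc(-c4ccc(Cn5ccnc5)cc4)c3c2)cc1NS(=O)(=O)c1ccc(F)cc1F` differs from compound 1 by 1H-imidazol-1-yl in place of cyclohexyl(ethyl)amino on a saturated chain carbon bound to an aromatic carbon. That single measured step exchanged one amine for another at the same place and moved nothing; the present change brings an aromatic group instead, and compound 3 is therefore expected to shift only modestly, at a 1.7-fold higher number from compound 1 to compound 3 (0.24 log units; within the scatter), to an estimated 35 nM within 12 nM to 100 nM.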

Compound 3, half-maximal inhibitory concentration: 30.8 nM
The estimate for compound 3 lay 1.1-fold (0.06 log units) above the measured number; the measured number falls inside the stated range.
By their numbers in this assay, from the lowest: compounds 2, 1 and 3 (each within the scatter of the next).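

In this assay the change to (1H-imidazol-1-yl)methyl gives a 1.5-fold higher number from compound 1 to compound 3 (0.18 log units; within the scatter) and, against the piperidine, a 2.0-fold higher number from compound 2 to compound 3 (0.30 log units; within the scatter). On a saturated chain carbon bound to an aromatic carbon, a five-membered aromatic ring with 2 hetero atoms can therefore stand in for either amine without a step beyond the scatter, so the earlier finding is no longer limited to exchanges of one amine for another. No measurement at hand accounts for this.

The compounds shown leave open whether a carboxylic acid or a morpholine at this place would stay within the scatter of these three. They also leave open whether 1H-imidazol-1-yl on a longer chain would do so.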